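Extending the terminal urea: compound 3 to compound 4

The compounds below may be only part of what the source reports. "The series", "measured", "known", "first", "only" and "open" are said of these compounds alone.

Measured so far:
Compound 1, `O=C(Nc1ccc(-c2noc(-c3cccc(NS(=O)(=O)c4cccc(Cl)c4)c3)n2)c(Cl)c1)c1cccnc1`: in a functional assay on MDA-MB-231 cells (Homo sapiens) for antiproliferative activity, read by MTT assay, with a stated time of 72 h (on this read-out higher numbers stand for weaker inhibition and lower numbers for stronger inhibition), compound 1 reaches only the assay limit, > 10000 nM.
Compound 2, `NC(=O)Nc1ccc(S(=O)(=O)Nc2cccc(-c3nc(-c4ccc(NC(=O)c5cccnc5)cc4Cl)no3)c2)cc1`: in this assay compound 2 gives 2800 nM.
Compound 3, `CNC(=O)Nc1ccc(S(=O)(=O)Nc2cccc(-c3nc(-c4ccc(NC(=O)c5cccnc5)cc4Cl)no3)c2)cc1`: in this assay compound 3 gives 1300 nM.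

Compound 3 holds the lowest of the two actual numbers in this assay; its nearest neighbour is compound 2, separated by a 2.2-fold lower number from compound 2 to compound 3 (0.33 log units; beyond the scatter), while compound 1 sits at a limit (the limit of > 10000 nM in this assay, at which 1 of the 3 values shown sits).

The unmeasured compound 4, `CCNC(=O)Nc1ccc(S(=O)(=O)Nc2cccc(-c3nc(-c4ccc(NC(=O)c5cccnc5)cc4Cl)no3)c2)cc1`, differs from compound 3 by methyl in place of hydrogen on a saturated chain carbon bound to an amide-type nitrogen. For the measured compounds named here, the one measured step that touches this part of the molecule is a 2.2-fold lower number from compound 2 to compound 3 (0.33 log units; beyond the scatter), a modest change from adding the first methyl. The larger steps of an at least 3.5-fold lower number from compound 1 to compound 2 (0.55 log units; beyond the scatter) and an at least 7.6-fold lower number from compound 1 to compound 3 (0.88 log units; beyond the scatter) concern replacing the 3-chlorophenyl on the sulfonyl sulfur and start from a limit, so they say little about a second methyl. Adding one more carbon to the methylcarbamoyl group is expected to give at most a small further lowering, likely within the scatter.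

Compound 4 is therefore estimated at 1000 nM, with a range from 450 nM to 2500 nM. The expected step of a 1.3-fold lower number from compound 3 to compound 4 (0.11 log units; within the scatter) is estimated to lie within the scatter.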

Compound 4, half-maximal inhibitory concentration: 3100 nM
Compound 4: the middle estimate sits 3.1-fold (0.49 log units) below what was measured; the measured number lies above the stated range.
By their numbers in this assay, from the lowest: compound 3; then compounds 2 and 4 (each within the scatter of the next). At a limit, above all of these: compound 1.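

Changing methyl to ethyl gives a 2.4-fold higher number from compound 3 to compound 4 (0.38 log units; beyond the scatter) in this assay, and with a 1.1-fold higher number from compound 2 to compound 4 (0.04 log units; within the scatter) the ethyl urea of compound 4 ends level with the unsubstituted urea of compound 2, so the lowering seen with methyl does not carry on to ethyl. Across hydrogen, methyl and ethyl on this nitrogen, the numbers therefore follow no steady trend with chain length, and only methyl stands apart from the other two. The ethylcarbamoyl group still keeps an at least 3.2-fold lower number from compound 1 to compound 4 (0.50 log units; beyond the scatter), a step read from the limit held by compound 1: the limit of > 10000 nM in this assay, at which 1 of the 4 values shown sits.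

Going by these compounds, whether a longer chain such as propyl, or a branched isopropyl or a cyclopropyl group, would raise the number further remains open. Also open, on these data alone, is how a terminal amine or a carboxylic acid on this chain would read in this assay.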